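This account rests on a few compounds, and the source may have more. Where it says the series, first, only, none or still open, it means among the compounds named here.

Compound 2 `O=S(=O)(NCCNCc1ccc(-c2ccccc2)cc1)c1cc(C(F)(F)F)cc(C(F)(F)F)c1` gives the lowest number among the three compounds measured in a functional assay on BE(2)-C cells (Homo sapiens) for inhibition, read by MTT assay, with a stated time of 72 h (on this read-out lower numbers stand for stronger inhibition of growth and higher numbers for weaker inhibition of growth), at 2700 nM. Compound 1 `O=S(=O)(NCCNCc1cccc2ccccc12)c1cc(C(F)(F)F)cc(C(F)(F)F)c1` gives 19000 nM in this assay, a gap from compound 2 that lies beyond the scatter. Compound 3 `CN(CCCNS(=O)(=O)c1cc(C(F)(F)F)cc(C(F)(F)F)c1)Cc1ccccc1` gives 28000 nM in this assay, the highest of the three numbers and likewise beyond the scatter from compound 2. Compound 4 `CC(C)(C)c1ccc(CNCCNS(=O)(=O)c2cc(C(F)(F)F)cc(C(F)(F)F)c2)cc1` has not yet been measured. It differs from compound 2 by tert-butyl in place of phenyl on an aromatic carbon, para to a large group. For the measured compounds named here, no pair of measured compounds differs in just this way, so the size of the step has no direct precedent among the three numbers. As the change is confined to the outermost group of compound 2 and leaves the shared core untouched, a step of modest size, or none beyond the scatter, is what one would expect. The estimated step from compound 2 to compound 4 of a 1.7-fold higher number from compound 2 to compound 4 (0.22 log units; within the scatter) leans toward a slight weakening. Compound 4 is therefore expected to give about 4500 nM in this assay, within a range from 1500 nM to 14000 nM.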

Compound 4, concentration for 50% growth inhibition: 14000 nM
Beside the measured number, compound 4's estimate is 3.1-fold (0.49 log units) below it; the range from low to high includes it.
By their numbers in this assay, from the lowest: compound 2; then compounds 4, 1 and 3 (each within the scatter of the next).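

In this assay, for the compounds shown here, tert-butyl in place of phenyl on an aromatic carbon, para to a large group, gives a 5.2-fold higher number from compound 2 to compound 4 (0.71 log units; beyond the scatter) and is the first change at a single place that can be read, showing that the outermost group of compound 2 is not a silent one and that the shared core alone does not set the number. The other new comparison, 4-(tert-butyl)phenyl in place of naphthalen-1-yl on a saturated chain carbon bound to an amine nitrogen, gives a 1.4-fold lower number from compound 1 to compound 4 (0.13 log units; within the scatter), so these two compounds cannot be told apart and, of the compounds compared here, only compound 2 stands clear of compound 4. Nothing measured here accounts for the loss on leaving phenyl for tert-butyl.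

From the compounds shown here alone, it remains open whether a cyclohexyl group at this place, a ring of the same size without the aromatic carbons, would side with compound 2 or with compound 4. Also open, going by these compounds, is whether a pyridine ring or a methoxy group on the outer phenyl would move the number further in either direction.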